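From compound 2 to compound 3: a phenyl swap

The source may hold more compounds than are shown below. What is called first, only, known or untested is meant among the compounds shown, and "the series" means these compounds.

Measured in an ADME assay on WI-38 cells (Homo sapiens) for cytotoxicity, read by MTT assay, with a stated time of 72 h; a lower number here means a stronger inhibitor, a higher number a weaker inhibitor:
Compound 1 `CC(=O)c1ccc(-c2cccc(NC(=O)CCc3ccc4c(c3)COB4O)c2)cc1`: > 100000 nM (a limit)
Compound 2 `CC(=O)c1ccc(-c2cccc(NC(=O)CCc3cccc4c3COB4O)c2)cc1`: > 100000 nM (a limit)

Neither entry is a number, and both compounds stand at the limit of > 100000 nM in this assay, at which 2 of the 2 values shown sit. Compound 3 `CC(=O)c1ccc(-c2cccc(NC(=O)CCc3ccccc3)c2)cc1` has not yet been measured. It differs from compound 2 by a group of 6 heavy atoms (6 carbon; one six-membered aromatic ring of carbon only) in place of a group of 10 heavy atoms (7 carbon, 1 boron, 2 oxygen; one five-membered non-aromatic ring with 2 hetero atoms, one six-membered aromatic ring of carbon only), on a saturated chain carbon, two bonds along the chain from a carbonyl carbon. Going by the values given here, only one measured step bears on this change: a step that the two limits leave unreadable from compound 1 to compound 2. Among the compounds with values here, its size cannot be read, and it exchanges one group of 10 heavy atoms for another, so no measured step shows the effect of phenyl in that place. Resting on the limit of compound 2 at > 100000 nM, no step beyond the scatter is expected in this assay, in either direction, and another limit is the likeliest report. The expected step is a number no higher from compound 2 to compound 3 (the limit leaves the size open). Compound 3 is estimated at 100000 nM, with an expected range of 40000 nM to 250000 nM.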

Compound 3, half-maximal inhibitory concentration: 13000 nM
Beside the measured number, compound 3's estimate is 7.7-fold (0.89 log units) above it; measured number outside the range, below it.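

In this assay, phenyl in place of the boron-bearing group on the saturated chain carbon, two bonds along the chain from a carbonyl carbon, gives an at least 7.6-fold lower number from compound 2 to compound 3 (0.88 log units; beyond the scatter), and in place of the other boron-bearing group it gives an at least 7.6-fold lower number from compound 1 to compound 3 (0.88 log units; beyond the scatter). The earlier pair could not show that this place can move the read-out at all, since the step between compound 1 and compound 2 cannot be read. With phenyl there, the read-out becomes a number rather than a limit, while the two boron-bearing compounds remain at a limit: the limit of > 100000 nM in this assay, at which 2 of the 3 values shown sit.

The compounds shown leave open whether the boron atom, the oxygens or the five-membered ring accounts for the step. They also leave open how a hydroxyl group or a carboxylic acid on the phenyl ring would read in this assay.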